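This account rests on a few compounds, and the source may have more. Where it says the series, first, only, none or still open, it means among the compounds named here.

Three compounds share one core and differ only in the aryl group attached to the amide carbonyl. Compound 1 `COc1ccccc1C(=O)Nc1cccc(-c2oc3cc(-c4ccc(F)cc4)ccc3c(=O)c2O)c1` gives 2100 nM in a functional assay on MCF7 cells (Homo sapiens) for antiproliferative activity, read by CCK-8 assay, with a stated time of 72 h; a lower number here means a stronger inhibitor, a higher number a weaker inhibitor. Compound 2 `COc1cccc(C(=O)Nc2cccc(-c3oc4cc(-c5ccc(F)cc5)ccc4c(=O)c3O)c2)c1` gives 15300 nM. Compound 3 `O=C(Nc1cccc(-c2oc3cc(-c4ccc(F)cc4)ccc3c(=O)c2O)c1)c1ccc(Cl)nc1` gives 2890 nM, which places it second highest of the three numbers, close to compound 1 and well apart from compound 2.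

The steps among them show that this position matters. Moving the methoxy group, a 7.3-fold higher number from compound 1 to compound 2 (0.86 log units; beyond the scatter), was a modest weakening. Exchanging the aryl group for a chlorinated pyridine, a 1.4-fold higher number from compound 1 to compound 3 (0.14 log units; within the scatter), stayed within the scatter, while the reverse comparison, a 5.3-fold lower number from compound 2 to compound 3 (0.72 log units; beyond the scatter), recovered most of what had been lost.

Compound 4 `N#Cc1ccc(C(=O)Nc2cccc(-c3oc4cc(-c5ccc(F)cc5)ccc4c(=O)c3O)c2)cc1` is made from compound 3 by a change at the same carbonyl carbon: 4-cyanophenyl in place of 6-chloropyridin-3-yl on a carbonyl carbon. Both groups carry a single hydrogen-bond acceptor and no donor, and both keep the substituent at the position that, in compound 1 and compound 3, gave the lower numbers. With one exchange at this position within the scatter and only the shifted methoxy group weakening the series, the expected step of a 1.0-fold higher number from compound 3 to compound 4 (0.02 log units; within the scatter) is small, in either direction. Compound 4 is therefore estimated at 3000 nM, with a range from 1200 nM to 8000 nM.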

Compound 4, half-maximal inhibitory concentration: 2660 nM
The estimate for compound 4 lay 1.1-fold (0.05 log units) above the measured number, and the stated range covers the measured number.
By their numbers in this assay, from the lowest: compounds 1, 4 and 3 (each within the scatter of the next); then compound 2.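

In this assay, exchanging the 6-chloropyridin-3-yl group, with its ring nitrogen and chlorine, for 4-cyanophenyl, with its carbon-only ring and nitrile, leaves the number within the scatter (a 1.1-fold lower number from compound 3 to compound 4 (0.04 log units; within the scatter)), so in this pair neither the ring nitrogen nor the chlorine is required for a value of this size. The comparison with the 2-methoxyphenyl group also stays within the scatter (a 1.3-fold higher number from compound 1 to compound 4 (0.10 log units; within the scatter)), while the gap to the 3-methoxyphenyl group lies beyond it (a 5.8-fold lower number from compound 2 to compound 4 (0.76 log units; beyond the scatter)), so three aryl groups now give numbers close to one another and 3-methoxyphenyl is the one that goes against this pattern. No measurement shown explains why these three groups behave alike or why 3-methoxyphenyl stands apart.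

Going by these compounds, all four groups on this carbonyl carbon are six-membered aromatic rings, so it remains open whether the activity survives with something other than such a ring, for example a short alkyl chain or a group carrying an amine or a carboxylic acid. On these data alone, it also remains open whether the weaker result of the 3-methoxyphenyl compound depends on the methoxy group itself, which a nitrile in its place on that ring would begin to test.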